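Bromo for Methyl on a Hydroxamic Acid Growth Inhibitor

A few compounds are considered here, and "the series" means these few. Any claim that something is new, unique, unknown or untested is made for them only; others in the source may bear on it.

Measured so far:
Compound 1 `Cc1cccc(CN2CC=C(CCC(=O)NO)C2=O)c1` — 4620 nM
Compound 2 `CCOc1ccc(CCCN2CC=C(CCC(=O)NO)C2=O)cc1` — 3480 nM

In a functional assay on PC-3 cells (Homo sapiens) for inhibition, read by sulforhodamine B assay (on this read-out higher numbers stand for weaker inhibition of growth and lower numbers for stronger inhibition of growth), compound 1 gives the higher of the two numbers, but compound 2 lies within the usual scatter of it, so the two cannot be told apart. Compound 3 `O=C(CCC1=CCN(Cc2cccc(Br)c2)C1=O)NO` has not been measured yet; it differs from compound 1 by bromo in place of methyl on an aromatic carbon. Among the compounds with values here, no measured pair shows what this change does in this assay, so the expected step of a 1.2-fold lower number from compound 1 to compound 3 (0.08 log units; within the scatter) is none beyond the scatter. Compound 3 is therefore estimated at 3800 nM, with a range from 1500 nM to 9500 nM.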

Compound 3, concentration for 50% growth inhibition: 4620 nM
The estimate for compound 3 lay 1.2-fold (0.08 log units) below the measured number, within the range that was stated.
By their numbers in this assay, from the lowest: compounds 2, 1 and 3 (each within the scatter of the next).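

Bromo in place of methyl on this aromatic carbon, meta to a large group, brings no change at the digits printed from compound 1 to compound 3 (within the scatter) in this assay. Within the data shown here, this pair gives the first direct reading of the change, and in this assay the two groups cannot be told apart at this position. Nothing measured here offers an explanation for this result.

From the compounds shown here alone, what an amine, a carboxylic acid or a longer chain on this same carbon would do remains open. So does whether bromo for methyl gives the same result on a different core.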